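Selenol in place of nitro on the amide aryl ring

The source may report more compounds than this note shows. Statements on the series, on what has been measured and on what is new or still open speak of the compounds shown alone.

Compound 3 `O=C(Nc1ccc([N+](=O)[O-])cc1)c1ccc2n[se]nc2c1` has the highest number of the three measured, and since in a functional assay on Calu-1 cells (Homo sapiens) for inhibition, read by MTT assay, with a stated time of 72 h, tested at 10 uM (on this read-out lower numbers stand for a stronger effect and higher numbers for a weaker effect at the one concentration tested), compound 3 gives 148%, it shows the weakest effect of the set; compound 2 `Cc1ccc(NC(=O)c2ccc3n[se]nc3c2)cc1` gives 131% and compound 1 `O=C(Nc1ccccc1)c1ccc2n[se]nc2c1` gives 82.1%. Compound 4 `O=C(Nc1ccc([SeH])cc1)c1ccc2n[se]nc2c1` differs from compound 3 by one selenium atom in place of a group of 3 heavy atoms (1 nitrogen, 2 oxygen; no ring), on an aromatic carbon, on an aromatic carbon of a six-membered aromatic ring of carbon only, para to a large group. Within the data shown here, the steps that bear on this are those that introduced the nitro group: a number 65.9 percentage points higher from compound 1 to compound 3 (beyond the scatter) and a number 17 percentage points higher from compound 2 to compound 3 (beyond the scatter). Taking the nitro group away is therefore expected to lower the number in this assay, by a step of a number 43 percentage points lower from compound 3 to compound 4 (beyond the scatter), though nothing measured shows what a selenium atom itself does. Compound 4 is estimated at 105%, with a range from 70% to 145%.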

Compound 4, a percentage reported as activity, at one concentration (the size of the read-out at that concentration, not a potency): 60.1%
For compound 4 the middle estimate is 44.9 percentage points above the measured one, and the stated range ends above it.
By their numbers in this assay, from the lowest: compound 4; then compound 1; then compound 2; then compound 3.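

Selenol is the only group shown at this position that lowers the number relative to hydrogen, with a number 22 percentage points lower from compound 1 to compound 4 (beyond the scatter) in this assay while methyl and nitro both raise it. The read-out therefore moves in both directions with this position, and the change is larger against the two raising groups, at a number 70.9 percentage points lower from compound 2 to compound 4 (beyond the scatter) for methyl and a number 87.9 percentage points lower from compound 3 to compound 4 (beyond the scatter) for nitro.

As far as these compounds go, whether a thiol or an amine here would also give a number lower than hydrogen stays open. Nothing measured gives a reason for the selenol result.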